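Working notes: one group exchanged on the more active compound

The source may report more compounds than this note shows. Statements on the series, on what has been measured and on what is new or still open speak of the compounds shown alone.

Measured in a functional assay on A549 cells (Homo sapiens) for antiproliferative activity, read by sulforhodamine B assay, with a stated time of 48 h; a lower number here means a stronger inhibitor, a higher number a weaker inhibitor:
- compound 1 `COc1cccc(/C=C/C(=O)/C=C(O)/C=C/c2cccc(OC)c2OC)c1OC` gives 11500 nM
- compound 2 `COc1cc(C=C(C(=O)/C=C/c2cccc(OC)c2OC)C(=O)/C=C/c2cccc(OC)c2OC)ccc1O` gives 130 nM

Of these two numbers, compound 2 holds the lower one at 130 nM, and the gap to compound 1 at 11500 nM lies beyond the scatter. Next in the series is compound 3 `COc1cccc(/C=C/C(=O)C(=Cc2cc(OC)c(OC)c(OC)c2)C(=O)/C=C/c2cccc(OC)c2OC)c1OC`. It carries 3,4,5-trimethoxyphenyl in place of 4-hydroxy-3-methoxyphenyl on a double-bonded chain carbon bound to a double-bonded chain carbon. For the measured compounds named here, no measured pair isolates this exchange, so the expectation rests only on compound 2 at 130 nM and remains loose. In this assay, the expected 1.7-fold higher number from compound 2 to compound 3 (0.23 log units; within the scatter) is small, towards a higher number, and may not exceed the scatter. For compound 3 the estimated value is 220 nM, with an expected range of 60 nM to 900 nM.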

Compound 3, half-maximal inhibitory concentration: 230 nM
Compound 3: middle estimate off by 1.0-fold (0.02 log units), on the low side, within the range that was stated.
By their numbers in this assay, from the lowest: compounds 2 and 3 (each within the scatter of the next); then compound 1.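

In this assay, 3,4,5-trimethoxyphenyl in place of 4-hydroxy-3-methoxyphenyl on a double-bonded chain carbon bound to a double-bonded chain carbon gives a step within the scatter (a 1.8-fold higher number from compound 2 to compound 3 (0.25 log units; within the scatter)), so this position accepts the exchange without a readable change. The leaving group has a hydrogen-bond donor and the entering group has none, so a donor on this group is not needed for a value in this range in this pair. No available measurement bears on the reason for this result.

On these data alone, whether an amine or a carboxylic acid on the aromatic ring at this position would stay in the same range remains open. For the compounds shown here, only one exchange can be read here, so how far this acceptance extends at this position, or elsewhere on the core of compound 2, is not settled.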